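Changing the chain end of compound 3

The source may report more compounds than this note shows. Statements on the series, on what has been measured and on what is new or still open speak of the compounds shown alone.

Measured in a physicochemical assay for solubility, in phosphate buffer, at pH 6.8; a lower number here means a less soluble compound, a higher number a more soluble compound:
Compound 1 `CC(C)(C)C(=O)C1=C(O)C(=O)N(c2ccc(-c3ccsc3)cc2)C1c1ccccc1OCCO`: > 50000 nM, a limit of the assay
Compound 2 `COc1ccccc1C1C(C(=O)C(C)(C)C)=C(O)C(=O)N1c1ccc(-c2ccsc2)cc1`: 900 nM
Compound 3 `COCCOc1ccccc1C1C(C(=O)C(C)(C)C)=C(O)C(=O)N1c1ccc(-c2ccsc2)cc1`: 22800 nM

Compound 3 has the higher of the two true numbers. Compound 1 stands at the limit of > 50000 nM in this assay, at which 1 of the 3 values shown sits, so it gives no exact number for comparison.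

Compound 4 `C[S+]([O-])CCOc1ccccc1C1C(C(=O)C(C)(C)C)=C(O)C(=O)N1c1ccc(-c2ccsc2)cc1` keeps the shared core and changes only the end of the chain. Methoxy leaves a saturated chain carbon, two bonds along the chain from an oxygen on an aromatic ring, and a new group takes its place: a group of 3 heavy atoms (1 carbon, 1 oxygen, 1 sulfur; no ring) in place of a group of 2 heavy atoms (1 carbon, 1 oxygen; no ring), on a saturated chain carbon, two bonds along the chain from an oxygen on an aromatic ring.

For the measured compounds named here, three measured steps bear on this change. Two of them remove or add part of the chain, and both are large: an at least 55-fold lower number from compound 1 to compound 2 (1.74 log units; beyond the scatter) and a 25-fold higher number from compound 2 to compound 3 (1.40 log units; beyond the scatter). The third alters only the chain end and is smaller, though at least modest: an at least 2.1-fold lower number from compound 1 to compound 3 (0.34 log units; beyond the scatter). That third step is the closest guide, since compound 4 also keeps the chain and alters its end. Going by the values given here, no measured compound carries the new end, so the direction is uncertain.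

In this assay, no change beyond the scatter is expected, with a slight lean upward. The estimated step is a 1.5-fold higher number from compound 3 to compound 4 (0.19 log units; within the scatter). For compound 4 the estimated value is 35000 nM, with an expected range from 12000 nM to 50000 nM.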

Compound 4, solubility: > 50000 nM
Compound 4 was reported as a limit; the forecaster's own chance of this, stated with the estimate: 35%; at least 1.4-fold (0.15 log units) between middle value and limit.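

In this assay compound 4 gives > 50000 nM, which is a limit of the assay and not an exact number. Putting the new group of 3 heavy atoms, which holds sulfur, in place of methoxy gives an at least 2.1-fold higher number from compound 3 to compound 4 (0.34 log units; beyond the scatter), and adding the whole chain end in place of hydrogen gives an at least 55-fold higher number from compound 2 to compound 4 (1.74 log units; beyond the scatter), so the high numbers at this place are not tied to the oxygen-ended chains of the earlier compounds, and among the compounds shown only compound 2, which lacks the chain, stays low. The step between compound 1 and compound 4 cannot be read, because both values are limits: the limit of > 50000 nM in this assay, at which 2 of the 4 values shown sit.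

The compounds shown leave open how far compound 1 and compound 4 truly lie past that limit, so these two chain ends cannot be ranked against each other. They also leave open whether an amine, a carboxylic acid or a longer chain at this place would keep the number as high.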